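A few compounds are considered here, and "the series" means these few. Any claim that something is new, unique, unknown or untested is made for them only; others in the source may bear on it.

The measured compounds in a functional assay on MGC-803 cells (Homo sapiens) for inhibition, read by MTT assay, with a stated time of 72 h; on this read-out lower numbers stand for stronger inhibition and higher numbers for weaker inhibition:

Compound 1, `CC(C)c1ccc(-c2nc(SCc3cn(CC(=O)NC(=O)Nc4ccccn4)nn3)nc(Nc3ccc(F)cc3)c2C#N)cc1`, gives 17500 nM.
Compound 2, `CC(C)c1ccc(-c2nc(SCc3cn(CC(=O)NC(=O)Nc4ccccn4)nn3)nc(Nc3ccc(Cl)cc3)c2C#N)cc1`, gives > 64000 nM, which is a limit of the assay and not a number.
Compound 3, `COc1ccc(Nc2nc(SCc3cn(CC(=O)NC(=O)Nc4ccccn4)nn3)nc(-c3ccc(C(C)C)cc3)c2C#N)cc1`, gives > 64000 nM, which is a limit of the assay and not a number.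

Compound 3 therefore stands at the weak end of what has been seen, at the limit of > 64000 nM in this assay, at which 2 of the 3 values shown sit. Compound 4, `Cc1ccc(Nc2nc(SCc3cn(CC(=O)NC(=O)Nc4ccccn4)nn3)nc(-c3ccc(C(C)C)cc3)c2C#N)cc1`, differs from it in one place: methyl in place of methoxy on an aromatic carbon. Within the data shown here, two measured steps bear on this change. The step of an at least 3.6-fold higher number from compound 1 to compound 3 (0.56 log units; beyond the scatter) shows that the methoxy compound sits far above the fluoro compound in this assay. The step that the two limits leave unreadable from compound 2 to compound 3, between the chloro and methoxy compounds, cannot be read, as both sit at the limit. Among the measured compounds shown here, no measured step shows a methyl group here. Since both the chloro and methoxy analogues sit at the limit and only the fluoro compound gives a number, compound 4 is expected to stay weak, with an at least 1.2-fold lower number from compound 3 to compound 4 (0.10 log units; that floor lies within the scatter), and its value is estimated at 50000 nM, ranging from 15000 nM to 150000 nM.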

Compound 4, half-maximal inhibitory concentration: 3360 nM
The estimate for compound 4 lay 15-fold (1.17 log units) above the measured number; measured number below the stated range.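

In this assay, among these compounds, the group on this aromatic carbon, para to a large group, matters more than the earlier compounds could show: methyl in place of methoxy gives an at least 19-fold lower number from compound 3 to compound 4 (1.27 log units; beyond the scatter), and methyl in place of chloro gives an at least 19-fold lower number from compound 2 to compound 4 (1.27 log units; beyond the scatter). Methyl also improves on fluoro, with a 5.2-fold lower number from compound 1 to compound 4 (0.72 log units; beyond the scatter), so fluoro is no longer the only group here to give a number. Compound 2 and compound 3 remain at a limit of the assay and not a number: the limit of > 64000 nM in this assay, at which 2 of the 4 values shown sit.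

The step between compound 2 and compound 3 still cannot be read. The compounds shown leave open whether an ethyl group, a trifluoromethyl group or a hydroxyl group at this place would match methyl or fall back to the limit.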